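The source may report more compounds than this note shows. Statements on the series, on what has been measured and on what is new or still open speak of the compounds shown alone.

Measured in an ADME assay for permeability, using PAMPA, at pH 7.4; on this read-out lower numbers stand for lower permeability and higher numbers for higher permeability:
- compound 1 `Cc1[nH]c2ccc(Cl)cc2c(=O)c1Cc1ccccc1`: 415 10^-6 cm/s
- compound 2 `COc1cccc2[nH]c(C)c(Cc3ccccc3)c(=O)c12`: 158 10^-6 cm/s
- compound 3 `COc1ccc2nc(C)c(Cc3ccccc3)c(OC)c2c1`: 1070 10^-6 cm/s

Compound 3 gives the highest number of the three, and both others lie below it by more than the usual scatter. Compound 4 `COc1c(Cc2ccccc2)c(C)nc2ccc(Cl)cc12` is the next compound to test. It differs from compound 3 by one change: chloro in place of methoxy on an aromatic carbon. Going by the values given here, no measured pair isolates this change. Compound 1, which carries chloro, at 415 10^-6 cm/s, reads higher than compound 2, which carries methoxy, at 158 10^-6 cm/s, but these two are no clean comparison. A step beyond the scatter, in either direction, is therefore not expected. The expected change, a 1.1-fold lower number from compound 3 to compound 4 (0.03 log units; within the scatter), is small. For compound 4 the estimate is 1000 10^-6 cm/s, with an expected range of 450 10^-6 cm/s to 2200 10^-6 cm/s.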

Compound 4, apparent permeability in the ADME assay: 268 10^-6 cm/s
Estimate against measurement, compound 4: 3.7-fold (0.57 log units) above; the measured number lies below the stated range.
By their numbers in the ADME assay, from the lowest: compounds 2, 4 and 1 (each within the scatter of the next, the first and the last beyond it); then compound 3.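

Going by these compounds alone, as the first clean pair for this change, it shows that in the ADME assay the swap is not neutral, giving a 4.0-fold lower number from compound 3 to compound 4 (0.60 log units; beyond the scatter). Within the data shown here, the loose hint from the earlier compounds, where the chloro compound read higher, does not hold in this direct comparison. In a physicochemical assay for lipophilicity, at pH 7.4 (on this read-out higher numbers stand for higher lipophilicity and lower numbers for lower lipophilicity), the same change moves upward, with compound 3 at 4.2 and compound 4 at 4.93, so here higher lipophilicity accompanies lower permeability: the measured distribution coefficient of compound 3, 4.2, and of compound 4, 4.93, a number 0.73 log units higher (beyond the scatter)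

One pair cannot show whether this link holds generally. As far as these compounds go, how a fluoro group, an amine or a carboxylic acid at this carbon would read on either scale remains open.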